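This account rests on a few compounds, and the source may have more. Where it says the series, first, only, none or still open, it means among the compounds named here.

Of the compounds shown here, two sharing one core have been tested in a functional assay on CHO cells for agonist activity at prostaglandin E2 receptor EP1 subtype (Homo sapiens), read by fluorescence and calcium flux; a higher number here means that more compound is needed for the effect, a lower number that less compound is needed. Compound 1, `O=C(O)c1csc([C@H]2CC[C@@H]3[C@@H](/C=C/COc4ccccc4)[C@H](O)C[C@@H]3O2)n1`, gives 700 nM in this assay. Compound 2, `O=C(O)c1csc([C@H]2CC[C@@H]3[C@@H](/C=C/[C@@H](O)COc4ccccc4)[C@H](O)C[C@@H]3O2)n1`, gives 1.4 nM in this assay. Among the compounds with values here, the only measured step, a 500-fold lower number from compound 1 to compound 2 (2.70 log units; beyond the scatter), is 1-hydroxy-2-phenoxyethyl in place of phenoxymethyl on a double-bonded chain carbon bound to a double-bonded chain carbon. On the numbers shown, compound 2 stands lowest of the two, its sole neighbour being compound 1 at a far higher number.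

Compound 3, `O=C(O)c1csc([C@H]2CC[C@@H]3[C@@H](/C=C/CCOc4ccccc4)[C@H](O)C[C@@H]3O2)n1`, has not yet been measured. It differs from compound 2 by hydrogen in place of hydroxy on a saturated chain carbon bound to a double-bonded chain carbon and a saturated chain carbon. The measured step of a 500-fold lower number from compound 1 to compound 2 (2.70 log units; beyond the scatter) bears directly on this: that change brought the hydroxy in and was large, whereas compound 3 keeps the extra chain carbon but drops the hydroxy. The expected result in this assay is a step back upward, a 210-fold higher number from compound 2 to compound 3 (2.33 log units; beyond the scatter), though not the whole way. Compound 3 still differs from compound 1 by one chain carbon. Compound 3 is thus estimated at 300 nM, with a range from 50 nM to 2000 nM.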

Compound 3, half-maximal effective concentration: 160 nM
Compound 3: middle estimate off by 1.9-fold (0.27 log units), on the high side, within the range that was stated.
By their numbers in this assay, from the lowest: compound 2; then compound 3; then compound 1.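

In this assay, removing the hydroxy from the saturated chain carbon bound to a double-bonded chain carbon and a saturated chain carbon takes back most of the earlier gain (a 110-fold higher number from compound 2 to compound 3 (2.06 log units; beyond the scatter)), so the 1-hydroxy-2-phenoxyethyl chain owes its low number largely to that single oxygen rather than to its length. The extra chain carbon alone, phenoxymethyl in place of phenoxy on a saturated chain carbon bound to a double-bonded chain carbon, gives a much smaller step (a 4.4-fold lower number from compound 1 to compound 3 (0.64 log units; beyond the scatter)), modest but still beyond the scatter, which splits the earlier single step (a 500-fold lower number from compound 1 to compound 2 (2.70 log units; beyond the scatter)) into a modest part from the chain carbon and a large part from the hydroxy. No measurement at hand explains why the hydroxy counts for so much.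

The compounds shown leave open whether a methoxy or an amine on that same saturated chain carbon would hold the low number of compound 2, and how the opposite configuration of the hydroxy would read. They also leave open whether the hydroxy gives a step of similar size when a longer chain or a benzyloxy group replaces the phenoxy end.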